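A few compounds are considered here, and "the series" means these few. Any claim that something is new, unique, unknown or untested is made for them only; others in the source may bear on it.

Three closely related compounds have so far been put through an ADME assay on MT4 cells (Homo sapiens) for cytotoxicity, read by MTT assay, with a stated time of 96 h; a higher number here means that more compound is tolerated, a lower number that less compound is tolerated. Compound 1 (`CC(=O)c1ccc2[nH]c(-c3ccccc3)nc2c1`) comes back as "not determined" (no result reported), so it offers no number to work with. Compound 2 (`C/C(=N\O)c1ccc2[nH]c(-c3ccc(C(F)(F)F)cc3)nc2c1`) is in the same position, reported as "not determined" (no result reported). For the measured compounds named here, compound 3 (`CC(=O)c1ccc2c(c1)nc(-c1ccccc1)n2C1CCCCC1`) gives 37000 nM, and this is the only real number available. Going by the values given here, it therefore cannot be ranked against anything, and no measured step shows how sensitive this read-out is to a structural change in these compounds.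

The next compound, compound 4 (`CC(=O)c1ccc2c(c1)nc(-c1ccc(C(F)(F)F)cc1)n2C1CCCCC1`), is compound 3 with a single alteration: trifluoromethyl in place of hydrogen on an aromatic carbon. In words, trifluoromethyl stands in place of hydrogen on an aromatic carbon, para to a large group, and the rest of the molecule is unchanged. Among the compounds with values here, with so small an edit and no precedent in the data, the sensible starting point is the parent value, which is compound 3 at 37000 nM. The expected result in this assay is a small change, a 1.3-fold lower number from compound 3 to compound 4 (0.12 log units; within the scatter), no larger than the usual scatter and, if anything, toward less compound tolerated. For compound 4 the estimated value is 28000 nM, with an expected range from 9000 nM to 80000 nM.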

Compound 4, half-maximal cytotoxic concentration: 41000 nM
The estimate for compound 4 lay 1.5-fold (0.17 log units) below the measured number, and the stated range covers the measured number.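

For the compounds shown here, this is the first measured step, and it gives the read-out a first sense of scale. In this assay, trifluoromethyl in place of hydrogen on an aromatic carbon, para to a large group, amounts to a 1.1-fold higher number from compound 3 to compound 4 (0.04 log units; within the scatter). A hydrogen atom has given way to a group of four heavy atoms, yet the step stays within the usual scatter, so at this one position the assay does not tell the two compounds apart, and nothing available explains this result.

On these data alone, one pair describes only one substituent at one position, so it remains open whether an amine or a carboxylic acid on the same aromatic carbon would also stay within the scatter, or would shift the number beyond it. Compound 1 and compound 2 provide no numbers, so any step involving them cannot be read, and the shown compounds cannot tell whether trifluoromethyl would behave the same way on a different version of the molecule.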